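Swapping ethyl for pyridin-2-yl on one nitrogen

The source may hold more compounds than are shown below. What is called first, only, known or untested is meant among the compounds shown, and "the series" means these compounds.

Of the compounds shown here, two sharing one core have been measured in a functional assay on HL-60 cells (Homo sapiens) for cytotoxicity, read by MTT assay, with a stated time of 3 days; on this read-out higher numbers stand for weaker inhibition and lower numbers for stronger inhibition. Compound 1 `N#Cc1c(NN)nc(SCc2nc3ccccc3[nH]2)nc1-c1ccccc1` gives 11.9 nM, and compound 2 `CCNc1nc(SCc2nc3ccccc3[nH]2)nc(-c2ccccc2)c1C#N` gives 3.96 nM, the lowest of the two numbers and so the stronger inhibition.

The next structure, compound 3 `N#Cc1c(Nc2ccccn2)nc(SCc2nc3ccccc3[nH]2)nc1-c1ccccc1`, keeps that core but has pyridin-2-yl in place of ethyl on a nitrogen on an aromatic ring. Going by the values given here, only one measured step bears on this change, made at the same nitrogen: a 3.0-fold lower number from compound 1 to compound 2 (0.48 log units; beyond the scatter). Among the compounds with values here, that step was modest, but it says little about adding a ring, and no measured compound carries one at this place. On that thin evidence, a change of similar modest size is expected in this assay, with an uncertain direction that leans towards a higher number, meaning weaker inhibition. The expected change is a 2.0-fold higher number from compound 2 to compound 3 (0.31 log units; beyond the scatter). For compound 3 the estimated value is 8 nM, with an expected range from 2 nM to 30 nM.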

Compound 3, half-maximal inhibitory concentration: 20 nM
Estimate against measurement, compound 3: 2.5-fold (0.40 log units) below; the measured number falls inside the stated range.
By their numbers in this assay, from the lowest: compound 2; then compounds 1 and 3 (each within the scatter of the next).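

In this assay, putting a ring on this nitrogen gives up inhibition: pyridin-2-yl in place of ethyl produces a 5.1-fold higher number from compound 2 to compound 3 (0.70 log units; beyond the scatter). Going by these compounds alone, until now, the only comparison at this nitrogen was between two small groups, so this is the first sign that a six-membered aromatic ring is tolerated less well here than ethyl, although inhibition stays in the same low range of numbers. Measured against the amino compound, pyridin-2-yl gives a 1.7-fold higher number from compound 1 to compound 3 (0.23 log units; within the scatter), so these two very different groups cannot be told apart in this read-out, and ethyl remains the best of the three groups at this position, with nothing available to explain the differences.

The compounds shown leave open whether the loss follows the ring as a whole or its ring nitrogen, a question that phenyl at the same nitrogen could help to settle. They also leave open whether the gain seen with ethyl continues along a longer chain such as propyl or butyl, or is lost as the chain grows.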